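Swapping 1-phenylethyl for 3-(methylamino)propyl: notes on the series

The source may report more compounds than this note shows. Statements on the series, on what has been measured and on what is new or still open speak of the compounds shown alone.

In a functional assay on HCT-116 cells (Homo sapiens) for cytotoxicity, read by MTT assay, with a stated time of 72 h (a higher number here means a weaker inhibitor, a lower number a stronger inhibitor), compound 3 `C[C@H](Nc1c(C(=O)NCc2ccc(F)cc2)nc(Br)c2cccnc12)c1ccccc1` gives > 20000 nM as a limit and not as a number. Compound 1 `Nc1cccc(Nc2c(C(=O)NCc3ccc(F)cc3)nc(Br)c3cccnc23)c1` gives > 10000 nM as a limit too. Compound 2 `O=C(NCCCNc1c(C(=O)NCc2ccc(F)cc2)nc(Br)c2cccnc12)c1ccccc1` carries an open chain on the same nitrogen and gives > 10000 nM as a limit too. Compound 3 therefore has no numerical position in this assay and only shares the limits of the other two. Within the data shown here, the one measured step (a step that the two limits leave unreadable from compound 1 to compound 3) has no readable size, so no measured size bears directly on the next change.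

Compound 4 `CNCCCNc1c(C(=O)NCc2ccc(F)cc2)nc(Br)c2cccnc12` has 3-(methylamino)propyl in place of 1-phenylethyl on a nitrogen on an aromatic ring. With compound 2 at > 10000 nM as a limit, an open chain in this place gives no reason to expect a strong inhibitor. The estimated step (an at least 1.6-fold lower number from compound 3 to compound 4 (0.22 log units; that floor lies within the scatter)) is expected to be small and toward a lower number, if it can be read at all. For compound 4 the estimate is 12000 nM with an expected range of 4000 nM to 30000 nM and a limit remains the likelier outcome.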

Compound 4, half-maximal inhibitory concentration: > 10000 nM
Compound 4 ended at the assay's limit (the forecaster's own chance of this, stated with the estimate: 65%); the middle value does not contradict the limit.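

In this assay compound 4 gives > 10000 nM, a limit and not a number. Its steps from compound 1, compound 2 and compound 3 cannot be read, since all four values are limits: the limit of > 10000 nM in this assay, at which 3 of the 4 values shown sit. The compounds shown leave open whether any group on this nitrogen gives a readable number.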